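Swapping acetyl for (pyridin-3-yl)carbonyl in compound 1

The source may hold more compounds than are shown below. What is called first, only, known or untested is meant among the compounds shown, and "the series" means these compounds.

- Compound 1 (`C=C1[C@H](OC(C)=O)C[C@@H](OC(C)=O)C(C)(C)/C=C/[C@@H](C)C(=O)[C@@]2(OC(C)=O)C[C@@](C)(OC(C)=O)[C@H](OC(C)=O)[C@@H]2[C@H]1OC(C)=O`) gives 13.5%
- Compound 2 (`C=C1[C@H](OCC(C)C)[C@@H](OC(C)=O)[C@@H](OC(C)=O)C(C)(C)/C=C/[C@@H](C)C(=O)[C@@]2(OC(C)=O)C[C@@](C)(OC(C)=O)[C@H](OC(C)=O)[C@@H]2[C@H]1OC(C)=O`) gives 23.3%

In a functional assay on MCF7 cells (Homo sapiens) for inhibition, read by MTT assay, with a stated time of 72 h, tested at 30 ug/mL (on this read-out lower numbers stand for less inhibition of growth and higher numbers for more inhibition of growth at the one concentration tested), compound 1 gives 13.5% and compound 2 gives 23.3% and the two lie within the usual scatter of each other. Compound 3 (`C=C1[C@H](OC(C)=O)C[C@@H](OC(=O)c2cccnc2)C(C)(C)/C=C/[C@@H](C)C(=O)[C@@]2(OC(C)=O)C[C@@](C)(OC(C)=O)[C@H](OC(C)=O)[C@@H]2[C@H]1OC(C)=O`) is not yet measured. It carries pyridin-3-yl in place of methyl on a carbonyl carbon of compound 1 (pyridin-3-yl in place of methyl on a carbonyl carbon), so acetyl becomes (pyridin-3-yl)carbonyl. Going by the values given here, no measured pair shows this change. The step expected in this assay is small and upward (a number 6.5 percentage points higher from compound 1 to compound 3 (within the scatter)) and should stay within the scatter. Estimated for compound 3 is a value of 20% (expected range 5% to 45%).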

Compound 3, percent growth inhibition at one concentration: 36.3%
Compound 3: middle estimate off by 16.3 percentage points, on the low side; low and high end bracket the measured number.
By their numbers in this assay, from the lowest: compounds 1 and 2 (each within the scatter of the next); then compound 3.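

In this assay, the change from acetyl to (pyridin-3-yl)carbonyl gives a number 22.8 percentage points higher from compound 1 to compound 3 (beyond the scatter), so this single swap moves the read-out by more than repeat measurements usually vary. At this acetoxy place on the shared core, a group with a six-membered aromatic ring is therefore accepted and goes with more growth inhibition, not less. Nothing shown here accounts for the rise. On these data alone, it remains open whether the gain needs the ring nitrogen, which a phenyl group at this place would test, and how a longer chain or an amine there would compare.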